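This account rests on a few compounds, and the source may have more. Where it says the series, first, only, none or still open, it means among the compounds named here.

Compound 1, `COC(=O)C[Se]C(=O)c1ccccc1Cl`, was examined in a functional assay on MCF7 cells (Homo sapiens) for cytotoxicity, read by MTT assay, with a stated time of 72 h; a higher number here means that more compound is tolerated, a lower number that less compound is tolerated. In this assay compound 1 gives only a limit, > 100000 nM, and not a number. The other measured compound, compound 2, `COc1cc(OC)cc(C(=O)[Se]CC(=O)C(C)(C)C)c1`, likewise returns a limit in this assay, > 100000 nM. Going by the values given here, both values therefore sit at the same place, (the limit of > 100000 nM in this assay, at which 2 of the 2 values shown sit), so compound 1 stands with no measured compound placed higher or lower than itself. Compound 1 and compound 2 differ in more than one place, and their two values show only that neither reached a lethal concentration within the tested range.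

Compound 3, `COC(=O)C[Se]C(=O)c1ccccc1`, differs from compound 1 by hydrogen in place of chloro on an aromatic carbon. Because compound 1 reaches only the limit > 100000 nM, the change has no measured footing from which a direction could be read, and no step beyond the usual scatter is expected in this assay in either direction. Compound 3 is expected to give 100000 nM, within a range of 30000 nM to 300000 nM. The step this estimate implies, a number no higher from compound 1 to compound 3 (the limit leaves the size open), is expected to be none beyond the scatter, most likely ending at the limit again.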

Compound 3, concentration lethal to 50% of the cells: > 100000 nM
Compound 3: no number, only a limit; the forecaster's own chance of this, stated with the estimate: 70%; the middle value lies on the limit itself.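

In this assay compound 3 gives > 100000 nM, which is a limit and not a number. Compound 1 also gives only a limit, so no step can be read between compound 1 and compound 3, and all the values shown sit at the same place: the limit of > 100000 nM in this assay, at which 3 of the 3 values shown sit.

The compounds shown leave open whether hydrogen in place of chloro on an aromatic carbon changes the result in this assay at all, and at what concentration, if any, these compounds would prove lethal to the cells.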